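Hydroxy to acetoxy on compound 3

The source may report more compounds than this note shows. Statements on the series, on what has been measured and on what is new or still open speak of the compounds shown alone.

In a functional assay on PC-3 cells (Homo sapiens) for cytotoxicity, read by colorimetric assay and MTT assay (on this read-out higher numbers stand for weaker inhibition and lower numbers for stronger inhibition), compound 1 (`COc1cc(OC)c2cc(-c3ccccc3)c(O)nc2c1`) gives 10000 nM and compound 2 (`COc1ccc(-c2cc3c(OC)cc(OC)cc3n(CC#N)c2=O)cc1`) gives 10000 nM while compound 3 (`COc1cc(OC)c2cc(-c3ccc(O)cc3)c(=O)n(C)c2c1`) gives 10000 nM on the same read-out. Compound 3 therefore stands level with compound 1 and compound 2 at the digits given, with no gap beyond the scatter on either side. No pair among these three differs in a single place, so the series offers no measured step to carry over.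

Compound 4 (`COc1cc(OC)c2cc(-c3ccc(OC(C)=O)cc3)c(=O)n(C)c2c1`) keeps the frame of compound 3 and makes one change: acetyl in place of hydrogen on an oxygen on an aromatic ring, or hydroxy to acetoxy (acetyl in place of hydrogen on an oxygen on an aromatic ring). The only anchor for an expectation is compound 3 at 10000 nM together with the two compounds level with it. In this assay the expected step is small (a 1.1-fold lower number from compound 3 to compound 4 (0.05 log units; within the scatter)) and is not expected to exceed the scatter, leaning, if at all, towards stronger inhibition. A report of compound 4 as a limit rather than a number remains possible. For compound 4 the estimated value is 9000 nM with an expected range of 3000 nM to 12000 nM on this read-out.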

Compound 4, half-maximal inhibitory concentration: 10000 nM
Compound 4: the middle estimate sits 1.1-fold (0.05 log units) below what was measured, within the range that was stated.
By their numbers in this assay, from the lowest: compounds 1, 2, 3 and 4 (each within the scatter of the next).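

In this assay, the series now has its first measured single-place step: hydroxy to acetoxy, acetyl in place of hydrogen on an oxygen on an aromatic ring, reads as no change at the digits printed from compound 3 to compound 4 (within the scatter). At this position, then, the hydrogen of the hydroxy group can give way to acetyl, with its added carbonyl, without any shift in the number beyond the scatter, and compound 4 gives 10000 nM. Nothing in the available data explains this flat result or says what happens to the acetoxy group during the assay.

One flat step at a single oxygen says little about the position as a whole, since only hydrogen and acetyl have been compared there. As far as these compounds go, whether a larger change on that oxygen, such as a longer chain ending in an amine or a carboxylic acid, would move the number beyond the scatter in this assay remains open.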